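Shortening the Chain on Compound 3 by One Carbon

The compounds below may be only part of what the source reports. "The series", "measured", "known", "first", "only" and "open" are said of these compounds alone.

Three compounds have been measured in a functional assay on L1210 cells (Mus musculus); on this read-out higher numbers stand for weaker inhibition and lower numbers for stronger inhibition:
compound 1 `CCc1cn([C@H]2C[C@@H]3OP(=O)(O)OC[C@H]3O2)c(=O)[nH]c1=O` — 55 ug/mL
compound 2 `CCCCCCCCc1cn([C@H]2C[C@@H]3OP(=O)(O)OC[C@H]3O2)c(=O)[nH]c1=O` — 164 ug/mL
compound 3 `CCCCCc1cn([C@H]2C[C@@H]3OP(=O)(O)OC[C@H]3O2)c(=O)[nH]c1=O` — > 500 ug/mL, which is a limit of the assay and not a number.

Compound 3 thus stands at the weak end of what has been measured, with only a limit on record (the limit of > 500 ug/mL in this assay, at which 1 of the 3 values shown sits). Compound 4 `CCCCc1cn([C@H]2C[C@@H]3OP(=O)(O)OC[C@H]3O2)c(=O)[nH]c1=O` differs from it by hydrogen in place of methyl on a saturated chain carbon, four bonds along the chain from an aromatic carbon. Two measured steps lead into compound 3: an at least 9.0-fold higher number from compound 1 to compound 3 (0.95 log units; beyond the scatter) and an at least 3.0-fold higher number from compound 2 to compound 3 (0.48 log units; beyond the scatter); the third, a 3.0-fold higher number from compound 1 to compound 2 (0.47 log units; beyond the scatter), runs between the other two. Compound 4 sits between compound 1 and compound 3 in chain length, so a number somewhere between them is expected, a step of an at least 2.2-fold lower number from compound 3 to compound 4 (0.35 log units; beyond the scatter). Compound 4 is expected to give about 220 ug/mL, within 60 ug/mL to 600 ug/mL.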

Compound 4, concentration for 50% inhibition: 28.4 ug/mL
Beside the measured number, compound 4's estimate is 7.7-fold (0.89 log units) above it, outside the stated range (below it).
By their numbers in this assay, from the lowest: compounds 4 and 1 (each within the scatter of the next); then compound 2. At a limit, above all of these: compound 3.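

In this assay, hydrogen in place of methyl, four bonds along the chain from an aromatic carbon, gives an at least 17-fold lower number from compound 3 to compound 4 (1.24 log units; beyond the scatter), so one carbon at this place separates a measurable number from an open-ended one. Compound 3 carries only a limit of the assay: the limit of > 500 ug/mL in this assay, at which 1 of the 4 values shown sits. The numbers do not follow chain length in one direction: there is a 5.8-fold lower number from compound 2 to compound 4 (0.76 log units; beyond the scatter) and, within the scatter, a 1.9-fold lower number from compound 1 to compound 4 (0.29 log units; within the scatter), and compound 3 goes against any steady trend.

Where the true number of compound 3 lies remains open. So does whether an amine or a carboxylic acid on this chain, or a longer chain than that of compound 2, would keep the number of compound 4.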